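Adding a Methyl to the Shared Core of Compound 3

A few compounds are considered here, and "the series" means these few. Any claim that something is new, unique, unknown or untested is made for them only; others in the source may bear on it.

Measured in a functional assay on ileum (Cavia porcellus) for antagonist activity; a lower number here means a stronger inhibitor, a higher number a weaker inhibitor:
Compound 1 `CC(=O)c1ccc(OCC(O)COc2ccc3c(O)c([N+](=O)[O-])c(=O)oc3c2)cc1O`: > 20000 nM (a limit of the assay)
Compound 2 `CC(=O)c1ccc(OCC(O)COc2ccc3c(O)c([N+](=O)[O-])c(=O)oc3c2)c(C)c1O`: 500 nM
Compound 3 `CCCc1c(OCC(O)COc2ccc3c(O)c([N+](=O)[O-])c(=O)oc3c2)ccc(C(C)=O)c1O`: 80 nM

Compound 3 is the strongest inhibitor of the three, at 80 nM. Its nearest neighbour is compound 2, and the gap is modest: a 6.3-fold lower number from compound 2 to compound 3 (0.80 log units; beyond the scatter). The value of compound 1 is only a limit.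

The next compound, compound 4 `CCCc1c(OCC(O)COc2ccc3c(O)c([N+](=O)[O-])c(=O)oc3c2C)ccc(C(C)=O)c1O`, keeps everything in compound 3 except for one methyl in place of hydrogen on an aromatic carbon of the shared core: methyl in place of hydrogen on an aromatic carbon.

Two measured steps are the same kind of swap or a close relative of it, and both are large: an at least 40-fold lower number from compound 1 to compound 2 (1.60 log units; beyond the scatter) and an at least 250-fold lower number from compound 1 to compound 3 (2.39 log units; beyond the scatter). Among the compounds with values here, both of those changes lie outside the shared core, however, and no measured compound carries a substituent at the new place. They therefore give only weak guidance here, and the modest 6.3-fold lower number from compound 2 to compound 3 (0.80 log units; beyond the scatter) suggests that gains shrink once compound 3 is reached. No step beyond the scatter is expected in this assay, with a slight lean towards a lower number: the expected change is a 1.3-fold lower number from compound 3 to compound 4 (0.12 log units; within the scatter). For compound 4 the estimated value is 60 nM, with an expected range from 15 nM to 250 nM.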

Compound 4, half-maximal inhibitory concentration: 25 nM
Compound 4: middle estimate off by 2.4-fold (0.38 log units), on the high side; the measured number falls inside the stated range.
By their numbers in this assay, from the lowest: compound 4; then compound 3; then compound 2. At a limit, above all of these: compound 1.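

In this assay, this is the first compound shown with a substituent at this place, on an aromatic carbon of the shared core, ortho to a fused ring and ortho to a large group, and the methyl there gives a step beyond the scatter: a 3.2-fold lower number from compound 3 to compound 4 (0.51 log units; beyond the scatter). The same swap of hydrogen for methyl at another place, outside the shared core, gave a much larger step, so its size in this assay depends on where it is made and on the compound that carries it: the same change on two cores in this assay, an at least 40-fold lower number (1.60 log units; beyond the scatter) from compound 1 to compound 2 and a 3.2-fold lower number (0.51 log units; beyond the scatter) from compound 3 to compound 4, at least 12-fold (1.09 log units) apart, beyond the scatter of two such steps Compound 1, at one end of that larger step, stands at a limit of the assay, so the larger step has no exact size: the limit of > 20000 nM in this assay, at which 1 of the 4 values shown sits.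

The compounds shown leave open whether a group other than methyl at this place, such as an ethyl, a methoxy or a chlorine, would lower the number further or raise it again. They also leave open whether the same methyl would give a step of like size on compound 2, which carries a methyl in place of the propyl of compound 3.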